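Methyl to Chloro on the Thiophene: Compound 3 Expected

This account rests on a few compounds, and the source may have more. Where it says the series, first, only, none or still open, it means among the compounds named here.

Compound 2 `COc1ccc(-c2csc(N3N=C(c4ccc(C)s4)CC3c3ccc(F)cc3)n2)cc1` — 184 ug/mL
Compound 1 `Fc1ccc(C2CC(c3ccc(Cl)s3)=NN2c2nc(-c3ccc(C(F)(F)F)cc3)cs2)cc1` — > 500 ug/mL

Going by the values given here, compound 2 `COc1ccc(-c2csc(N3N=C(c4ccc(C)s4)CC3c3ccc(F)cc3)n2)cc1` is the only one of the pair with a number in a functional assay on A549 cells (Homo sapiens) for antiproliferative activity, read by XTT assay, with a stated time of 24 h (a lower number here means a stronger inhibitor, a higher number a weaker inhibitor), where compound 2 gives 184 ug/mL. Compound 1 `Fc1ccc(C2CC(c3ccc(Cl)s3)=NN2c2nc(-c3ccc(C(F)(F)F)cc3)cs2)cc1` returns only a limit in this assay: compound 1 gives > 500 ug/mL, which is a limit and not a number (the limit of > 500 ug/mL in this assay, at which 1 of the 2 values shown sits). Compound 3 `COc1ccc(-c2csc(N3N=C(c4ccc(Cl)s4)CC3c3ccc(F)cc3)n2)cc1` carries the change (chloro in place of methyl on an aromatic carbon). Among the compounds with values here, no measured step shows what this change does here. The step from compound 2 to compound 3 is expected to be small, a 1.4-fold higher number from compound 2 to compound 3 (0.13 log units; within the scatter), at most a modest weakening near the scatter. Compound 3 is estimated at 250 ug/mL, between 100 ug/mL and 600 ug/mL.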

Compound 3, half-maximal inhibitory concentration: > 500 ug/mL
Compound 3 was reported as a limit (the forecaster's own chance of this, stated with the estimate: 30%); at least 2.0-fold (0.30 log units) between middle value and limit.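

Replacing 5-methylthiophen-2-yl with 5-chlorothiophen-2-yl is not a neutral change in this assay: it gives an at least 2.7-fold higher number from compound 2 to compound 3 (0.43 log units; beyond the scatter). The value of compound 3 is a limit and not a number, so this step has a floor but no measured size, and the step between compound 1 and compound 3 cannot be read. Compound 3 joins the values held at the assay's limit: the limit of > 500 ug/mL in this assay, at which 2 of the 3 values shown sit.

From the compounds shown here alone, how far compound 3 lies past its limit stays open. The compounds shown also do not tell whether an ethyl chain, a bromo or an amine at this place would keep the activity of compound 2.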